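From ethoxycarbonyl to methylcarbamoyl on the core of compound 1

This account rests on a few compounds, and the source may have more. Where it says the series, first, only, none or still open, it means among the compounds named here.

Compound 1, `CCOC(=O)CC(=O)N1CCSC1COc1ccccc1OC`: 11 mg/kg
Compound 2, `O=C(O)[C@@H]1CSC(CCc2ccccc2O)N1`: 45 mg/kg
Compound 3, `COc1ccccc1OCC1N(C(=O)CS(C)(=O)=O)CC[S+]1[O-]`: 28 mg/kg

Of the compounds shown here, three have been measured in a functional assay on the whole organism (trachea) for inhibition, with Cavia porcellus as the target; on this read-out higher numbers stand for an effect only at larger amounts of compound and lower numbers for an effect already at smaller amounts. Compound 1 gives 11 mg/kg, the lowest of the three numbers. The nearest is compound 3, whose number lies beyond the scatter above it; the furthest is compound 2, also beyond the scatter. The two other compounds share no single-point difference with compound 1, so their values show only where compound 1 stands, not what any one change does.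

Compound 4, `CNC(=O)CC(=O)N1CCSC1COc1ccccc1OC`, has not yet been measured. It differs from compound 1 in one place: methylamino in place of ethoxy on a carbonyl carbon. Going by the values given here, no pair of measured compounds covers a change of this kind, so nothing in this assay tells how large such a step usually is. The expected step is a 1.3-fold higher number from compound 1 to compound 4 (0.10 log units; within the scatter), which is none beyond the scatter, with a wide range to allow for the lack of a precedent. Compound 4 is estimated at 14 mg/kg, expected to fall between 5 mg/kg and 40 mg/kg.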

Compound 4, dose for half-maximal effect: 22 mg/kg
For compound 4 the middle estimate is 1.6-fold (0.20 log units) below the measured one, within the range that was stated.
By their numbers in this assay, from the lowest: compounds 1, 4, 3 and 2 (each within the scatter of the next, the first and the last beyond it).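

In this assay, going by these compounds alone, the exchange of ethoxy for methylamino on a carbonyl carbon gives a 2.0-fold higher number from compound 1 to compound 4 (0.30 log units; within the scatter) and is the first comparison in this set that isolates a single change on the core of compound 1. At this position, then, replacing ethoxycarbonyl with methylcarbamoyl, which also swaps a hydrogen-bond acceptor for a hydrogen-bond donor in the counted groups, leaves the two compounds within the scatter of each other. Nothing measured here bears on the reason for this result.

Going by these compounds, whether a carboxylic acid, a dimethylamino group or a longer alkoxy chain on the same carbonyl carbon would also stay within the scatter of compound 1 remains open. Within the data shown here, with only one pair showing this exchange, it is also unknown whether methylamino in place of ethoxy would give a similar step on another core.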